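This account rests on a few compounds, and the source may have more. Where it says the series, first, only, none or still open, it means among the compounds named here.

Working notes on the series. In a functional assay on DU-145 cells (Homo sapiens) for inhibition, read by trypan blue exclusion, with a stated time of 96 h (on this read-out lower numbers stand for stronger inhibition of growth and higher numbers for weaker inhibition of growth), compound 3 `COc1ccc(/C=C(\C(=O)c2ccc(Cl)cc2)S(=O)(=O)c2ccc(Br)cc2)cc1` gives 10000 nM, level with compound 2 `O=C(/C(=C\c1ccc(O)c([N+](=O)[O-])c1)S(=O)(=O)Cc1ccccc1Cl)c1ccc(Cl)cc1` at 10000 nM. Compound 1 `COc1cc(/C=C(\C(=O)c2ccc(Cl)cc2)S(=O)(=O)Cc2ccccc2Cl)cc(OC)c1` reads > 100000 nM, which is a limit of the assay and not a number.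

The next change leads to compound 4 `COc1ccc(/C=C(\C(=O)c2ccc(Cl)cc2)S(=O)(=O)Cc2ccccc2Cl)cc1`, with 2-chlorobenzyl in place of 4-bromophenyl on a sulfonyl sulfur. The rest of compound 3 is kept.

Among the measured compounds shown here, only one measured step is available, an at least 10-fold lower number from compound 1 to compound 2 (1.00 log units; beyond the scatter). It keeps 2-chlorobenzyl fixed and alters the group on the double-bonded chain carbon, so it bears on this change only indirectly. It shows that the 2-chlorobenzyl group can occur with a measurable value in this assay, but also with a limit. For the measured compounds named here, no measured step tests the sulfonyl substituent itself.

No large shift is therefore expected in this assay, with any movement more likely toward weaker inhibition of growth. The expected step is a 1.5-fold higher number from compound 3 to compound 4 (0.18 log units; within the scatter). The estimate for compound 4 is 15000 nM, with an expected range from 4000 nM to 60000 nM.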

Compound 4, concentration for 50% growth inhibition: 50000 nM
Compound 4: the middle estimate sits 3.3-fold (0.52 log units) below what was measured; the measured number falls inside the stated range.
By their numbers in this assay, from the lowest: compounds 2 and 3 (each within the scatter of the next); then compound 4. At a limit, above all of these: compound 1.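

In this assay, the sulfonyl substituent is now tested directly, and a 5.0-fold higher number from compound 3 to compound 4 (0.70 log units; beyond the scatter) shows that 2-chlorobenzyl in place of 4-bromophenyl on a sulfonyl sulfur gives weaker inhibition of growth. With 2-chlorobenzyl held fixed, a 5.0-fold higher number from compound 2 to compound 4 (0.70 log units; beyond the scatter) shows that 4-methoxyphenyl in place of 4-hydroxy-3-nitrophenyl also weakens inhibition, so both places in the series move the number. The reading of an at least 2.0-fold lower number from compound 1 to compound 4 (0.30 log units; that floor lies within the scatter) gives only a floor, and the comparison stays open-ended: the limit of > 100000 nM in this assay, at which 1 of the 4 values shown sits.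

The step at the sulfonyl sulfur changes the halogen, its place on the ring and the attachment through a methylene at once, and the compounds shown do not separate these. From the compounds shown here alone, how an unsubstituted benzyl or a 4-bromobenzyl group would read on that sulfur remains open.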